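A furan ring in place of a pent-1-yn-1-yl chain

The compounds below may be only part of what the source reports. "The series", "measured", "known", "first", "only" and "open" are said of these compounds alone.

Compound 1 `CCCC#Cc1cc([C@@H]2O[C@H](CO)[C@@H](O)[C@H]2O)n2ncnc(N)c12` carries a pent-1-yn-1-yl group on its core. In a functional assay on NCI-H460 cells (Homo sapiens) for antiproliferative activity, with a stated time of 72 h (a lower number here means a stronger inhibitor, a higher number a weaker inhibitor), compound 1 gives 400 nM, the lowest of the two numbers shown. Its nearest neighbour is compound 3 `COc1ccc(-c2cc([C@@H]3O[C@H](CO)[C@@H](O)[C@H]3O)n3ncnc(N)c23)cc1`, which in this assay gives 69300 nM. Compound 2 `Nc1ncnn2c([C@@H]3O[C@H](CO)[C@@H](O)[C@H]3O)cc(-c3ccccc3F)c12` is reported in this assay only as > 100000 nM, which is a limit of the assay and not a number. One value therefore rests at the limit of > 100000 nM in this assay, at which 1 of the 3 values shown sits.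

Two measured steps describe what happens when the pent-1-yn-1-yl group gives way to an aromatic ring: an at least 250-fold higher number from compound 1 to compound 2 (2.39 log units; beyond the scatter), and a 170-fold higher number from compound 1 to compound 3 (2.24 log units; beyond the scatter). The two aryl compounds themselves differ little: an at least 1.4-fold lower number from compound 2 to compound 3 (0.15 log units; that floor lies within the scatter).

Compound 4 `Nc1ncnn2c([C@@H]3O[C@H](CO)[C@@H](O)[C@H]3O)cc(-c3ccoc3)c12` differs from compound 1 by furan-3-yl in place of pent-1-yn-1-yl on an aromatic carbon. Furan-3-yl is once more a five-membered aromatic ring standing where the chain stood, so both measured aryl steps bear on this change, and both were large and upward. A comparable loss is expected for compound 4, and the estimated step is a 75-fold higher number from compound 1 to compound 4 (1.88 log units; beyond the scatter), with a real chance that only a limit is reported. Compound 4 is therefore estimated at 30000 nM in this assay, expected to lie between 5000 nM and 150000 nM.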

Compound 4, half-maximal inhibitory concentration: 1500 nM
Estimate against measurement, compound 4: 20-fold (1.30 log units) above; the whole stated range lies above it.
By their numbers in this assay, from the lowest: compound 1; then compound 4; then compound 3. At a limit, above all of these: compound 2.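

At this position, on an aromatic carbon of the five-membered aromatic ring of the core, an aromatic ring does not in itself bring a large loss: in this assay, the step to furan-3-yl is a 3.8-fold higher number from compound 1 to compound 4 (0.57 log units; beyond the scatter), which is beyond the scatter but only modest. The large losses go with the two substituted phenyl groups, since furan-3-yl in their place gives a 46-fold lower number from compound 3 to compound 4 (1.66 log units; beyond the scatter) and an at least 66-fold lower number from compound 2 to compound 4 (1.82 log units; beyond the scatter), so the kind of ring decides the outcome here, and furan-3-yl stands much closer to pent-1-yn-1-yl than to either 2-fluorophenyl or 4-methoxyphenyl. Compound 2 is held at a limit of the assay and not a number, so its step gives only a floor: the limit of > 100000 nM in this assay, at which 1 of the 4 values shown sits.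

The compounds shown leave open whether an unsubstituted phenyl group would behave like furan-3-yl or like the two substituted phenyl groups, and whether the ring oxygen matters, which thiophen-3-yl or furan-2-yl in the same place could test. They also leave open how far pent-1-yn-1-yl itself can be changed, for instance to a shorter alkynyl chain such as prop-1-yn-1-yl.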